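The compounds below may be only part of what the source reports. "The series", "measured", "known", "first", "only" and "open" are said of these compounds alone.

In a functional assay on C-33-A cells (Homo sapiens) for antiproliferative activity, read by MTT assay (a lower number here means a stronger inhibitor, a higher number a weaker inhibitor), three compounds have been measured so far:

Compound 1 `c1ccc(N2CCN(c3nc(-n4ccc5ccccc54)c4ccccc4n3)CC2)cc1` gives 50 ug/mL
Compound 2 `COc1cc(OC)c(-c2nc(N3CCN(C)CC3)nc3ccccc23)c(OC)c1` gives 50 ug/mL
Compound 3 `Cn1cc(-c2nc(N3CCNCC3)nc3ccccc23)c2ccccc21` gives 50 ug/mL

Compound 3 stands level with compound 1 and compound 2 on these numbers, so the three cannot be told apart in this assay at present. The next compound, compound 4 `CN1CCN(c2nc(-c3cn(C)c4ccccc34)c3ccccc3n2)CC1`, keeps everything in compound 3 except one place: methyl in place of hydrogen on an amine nitrogen in a ring. In words, a methyl takes the place of a hydrogen on an amine nitrogen in a ring, turning piperazin-1-yl into 4-methylpiperazin-1-yl.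

Among the compounds with values here, no two measured compounds differ in just one place, so this change has no direct measured precedent. The best guide is compound 3 at 50 ug/mL together with compound 2 at 50 ug/mL, which also carries a 4-methylpiperazin-1-yl group. The estimated change, a 1.1-fold lower number from compound 3 to compound 4 (0.05 log units; within the scatter), is expected to stay within the usual scatter, in neither direction. For compound 4 the expected value is 45 ug/mL, with an estimated range from 20 ug/mL to 90 ug/mL in this assay.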

Compound 4, half-maximal inhibitory concentration: 50 ug/mL
Beside the measured number, compound 4's estimate is 1.1-fold (0.05 log units) below it, and the stated range covers the measured number.
By their numbers in this assay, from the lowest: compounds 1, 2, 3 and 4 (each within the scatter of the next).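

In this assay, the change of hydrogen to methyl on the amine nitrogen in a ring gives no change at the digits printed from compound 3 to compound 4 (within the scatter). Within the data shown here, this is the first pair here that differs in just one place, so it gives a direct reading: on this core, turning piperazin-1-yl into 4-methylpiperazin-1-yl leaves the number where it was. No supporting measurement bears on why this is so.

The compounds shown leave open whether a larger group on the same nitrogen, such as an acetyl group or a longer chain ending in a carboxylic acid, would shift the number. Going by these compounds, all four compounds also print the same value, so it remains unknown whether the methyl would make a difference on a compound with a clearly lower number in this assay.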